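Amide side chain variation in the antiproliferative series

The compounds below may be only part of what the source reports. "The series", "measured", "known", "first", "only" and "open" are said of these compounds alone.

Going by the values given here, compound 2 `CCn1c(C(=O)NCCN(C)C)ccc1C(CC)(CC)c1ccc(OCCC(O)(CC)CC)c(C)c1` stands second highest of the three numbers measured so far in a functional assay on HepG2 cells (Homo sapiens) for antiproliferative activity, read by MTT assay, with a stated time of 48 h (a lower number here means a stronger inhibitor, a higher number a weaker inhibitor), where compound 2 gives 240 nM. Compound 1 `CCn1c(C(=O)NCCCN(C)C)ccc1C(CC)(CC)c1ccc(OCCC(O)(CC)CC)c(C)c1` gives 110 nM in this assay, and compound 3 `CCn1c(C(=O)NCCN)ccc1C(CC)(CC)c1ccc(OCCC(O)(CC)CC)c(C)c1` gives 1590 nM. All measured steps alter the group carried on the amide-type nitrogen: a 2.2-fold higher number from compound 1 to compound 2 (0.34 log units; beyond the scatter), a 14-fold higher number from compound 1 to compound 3 (1.16 log units; beyond the scatter) and a 6.6-fold higher number from compound 2 to compound 3 (0.82 log units; beyond the scatter). Compound 4 `CCn1c(C(=O)N(CCC#N)CCC#N)ccc1C(CC)(CC)c1ccc(OCCC(O)(CC)CC)c(C)c1` differs from compound 2 at the same carbonyl carbon: a group of 9 heavy atoms (6 carbon, 3 nitrogen; no ring) in place of a group of 6 heavy atoms (4 carbon, 2 nitrogen; no ring), on a carbonyl carbon. Among the compounds with values here, no measured step exchanges the whole amine-bearing chain for chains ending in nitriles, so the bearing of the measured steps is indirect. What they show is that every departure from the group of compound 1 has raised the number, and the larger departure in compound 3 raised it most. A step of comparable size in the same direction is therefore expected for compound 4, a 6.3-fold higher number from compound 2 to compound 4 (0.80 log units; beyond the scatter). Compound 4 is estimated at 1500 nM, with a range from 400 nM to 6000 nM.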

Compound 4, half-maximal inhibitory concentration: 46300 nM
The estimate for compound 4 lay 31-fold (1.49 log units) below the measured number, and the stated range ends below it.
By their numbers in this assay, from the lowest: compound 1; then compound 2; then compound 3; then compound 4.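

The carbonyl carbon proves far less forgiving in this assay than the three amine-bearing chains suggested, with a 190-fold higher number from compound 2 to compound 4 (2.29 log units; beyond the scatter) and a 29-fold higher number from compound 3 to compound 4 (1.46 log units; beyond the scatter) and also a 420-fold higher number from compound 1 to compound 4 (2.62 log units; beyond the scatter) on the same change of group. Each of these steps exceeds the largest step among compound 1, compound 2 and compound 3, so the choice of amine on the chain accounts for less of the spread than the exchange of the amine-bearing chain for nitrile-ended chains. That exchange removes the amine and the amide hydrogen together, and nothing at hand gives a reason for the size of the loss.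

On these data alone, the separate shares of the lost amine, the lost amide hydrogen and the added nitriles remain open. Also open, as far as these compounds go, is whether a single nitrile-ended chain that keeps the amide hydrogen, or a longer dimethylamino chain, would hold the number of compound 1.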